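This account rests on a few compounds, and the source may have more. Where it says the series, first, only, none or still open, it means among the compounds named here.

Compound 1 `COc1cc2nc(N3CCC(OCCO)CC3)nc(N)c2cc1OC` gives 2.2 nM in an assay on brain for displacement of a labelled ligand from Adrenergic receptor alpha-1 (Rattus norvegicus); a lower number here means a stronger inhibitor, a higher number a weaker inhibitor. Compound 2 `COc1cc2nc(N3CCC(OCC(C)O)CC3)nc(N)c2cc1OC` carries methyl in place of hydrogen on a saturated chain carbon bound to an oxygen on a saturated carbon and a saturated chain carbon and gives 3.52 nM in this assay; that change made a 1.6-fold higher number from compound 1 to compound 2 (0.20 log units; within the scatter). Compound 3 `CCOC(COC1CCN(c2nc(N)c3cc(OC)c(OC)cc3n2)CC1)c1ccccc1` has a different core, set apart from compound 1 by ethoxy(phenyl)methyl in place of hydroxymethyl on a saturated chain carbon bound to an oxygen on a saturated carbon; in this assay compound 3 gives 0.52 nM, a step of a 4.2-fold lower number from compound 1 to compound 3 (0.63 log units; beyond the scatter). Compound 4 `CCOC(C)(COC1CCN(c2nc(N)c3cc(OC)c(OC)cc3n2)CC1)c1ccccc1` differs from compound 3 by methyl in place of hydrogen on a saturated chain carbon bound to an aromatic carbon, an oxygen on a saturated carbon and a saturated chain carbon. This is the same kind of change as from compound 1 to compound 2, but not at the same place: in compound 3 the carbon that takes the methyl is also bound to an aromatic carbon, whereas in compound 1 it is bound only to an oxygen on a saturated carbon and a saturated chain carbon. For compound 4 the expected step is a 1.5-fold higher number from compound 3 to compound 4 (0.19 log units; within the scatter), resting on a 1.6-fold higher number from compound 1 to compound 2 (0.20 log units; within the scatter). Compound 4 is estimated at 0.8 nM in this assay.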

Compound 4, inhibition constant: 0.15 nM
Beside the measured number, compound 4's estimate is 5.3-fold (0.73 log units) above it; the measured number lies below the stated range.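

Methyl in place of hydrogen did not carry over as one fixed step from one core to the other in this assay: the same change on two cores in this assay, a 1.6-fold higher number (0.20 log units; within the scatter) from compound 1 to compound 2 and a 3.5-fold lower number (0.54 log units; beyond the scatter) from compound 3 to compound 4, 5.5-fold (0.74 log units) apart, beyond the scatter of two such steps

On the core of compound 3 the methyl alone gives a 3.5-fold lower number from compound 3 to compound 4 (0.54 log units; beyond the scatter), whereas the wider steps, a 23-fold lower number from compound 2 to compound 4 (1.37 log units; beyond the scatter) with 1-ethoxy-1-phenylethyl in place of 1-hydroxyethyl and a 15-fold lower number from compound 1 to compound 4 (1.17 log units; beyond the scatter) with that group in place of hydroxymethyl, involve more than the methyl. With a single pair on each core, this shows that the step differs between these two cores, but not which difference between the cores accounts for the gap, nor how the change would behave on any other core.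

From the compounds shown here alone, whether an ethyl group would follow the methyl remains open. So does the effect of an amine in place of the ethoxy group.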